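The compounds below may be only part of what the source reports. "The series", "measured", "known", "first", "only" and "open" are said of these compounds alone.

Of the compounds shown here, three of a shared macrocyclic peptide core have been measured in an ADME assay for pharmacokinetics, at 140 degrees C; a higher number here means that the compound lasts longer, a lower number that the compound disappears faster. Compound 1, `COC(=O)[C@H]1NC(=O)[C@@H](c2ccc(OC)c(Br)c2)NC(=O)[C@H](NC(=O)OC(C)(C)C)c2cc(O)c(OC)c(c2)Oc2ccc(cc2[N+](=O)[O-])[C@H]1O[Si](C)(C)C(C)(C)C`, gives 3.52 h and has the highest number of the three. Compound 2, `COc1ccc(C(NC(=O)[C@@H]2NC(=O)[C@H](NC(=O)OC(C)(C)C)[C@H](O)c3ccc(c(Cl)c3)Oc3cc(cc(O)c3OC)[C@H](C(=O)OC(C)(C)C)NC2=O)c2ccc(OC)cc2)cc1`, gives 0.15 h, and compound 3, `COc1c(O)cc2cc1Oc1ccc(cc1[N+](=O)[O-])[C@@H](O)[C@@H](NC(=O)OC(C)(C)C)C(=O)N[C@@H](CC(N)=O)C(=O)N[C@H]2C(=O)OC(C)(C)C`, gives 0.092 h; the gap from compound 1 to either of them lies beyond the usual scatter of repeated measurements, so compound 1 does stand apart from both. Going by the values given here, compound 2 and compound 3 differ from compound 1 in more than one place, so no single structural step between measured compounds can be read off from these three numbers.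

Compound 4, `COC(=O)[C@H]1NC(=O)[C@@H](c2ccc(OC)c(Br)c2)NC(=O)[C@H](NC(=O)OC(C)(C)C)c2cc(O)c(OC)c(c2)Oc2ccc(cc2Cl)[C@H]1O[Si](C)(C)C(C)(C)C`, is compound 1 with one change: chloro in place of nitro on an aromatic carbon. Among the compounds with values here, no measured pair shows what this exchange does in this assay, so there is no direct precedent to lean on. In the absence of such a step, the expected change from compound 1 to compound 4 is estimated as a 1.3-fold lower number from compound 1 to compound 4 (0.10 log units; within the scatter), a step not clearly beyond the scatter in either direction. Compound 4 is therefore expected to give about 2.8 h in this assay, with an estimated range from 1 h to 7 h reflecting the lack of a measured step for this change.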

Compound 4, half-life: 4.03 h
The estimate for compound 4 lay 1.4-fold (0.16 log units) below the measured number; the range from low to high includes it.
By their numbers in this assay, from the lowest: compounds 3 and 2 (each within the scatter of the next); then compounds 1 and 4 (each within the scatter of the next).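

In this assay, going by these compounds alone, chloro in place of nitro on this aromatic carbon gives a 1.1-fold higher number from compound 1 to compound 4 (0.06 log units; within the scatter) and this is the first step in the set that changes a single place, so the effect of one group can be read directly. It shows that three heavy atoms, including two hydrogen-bond acceptors and a double bond, can give way to a single chlorine atom at this position of the core of compound 1 without a change in half-life that stands clear of the scatter. Nothing measured here explains why the number holds.

The compounds shown do not tell whether an amine, a carboxylic acid or a longer chain on this same carbon would also leave the half-life where it is, or would move it beyond the scatter. They also leave open whether the exchange of nitro for chloro would behave the same way in compound 2 or compound 3, which differ from compound 1 in more than one place.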